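Swapping one acid-bearing group on the amide for another

The source may report more compounds than this note shows. Statements on the series, on what has been measured and on what is new or still open speak of the compounds shown alone.

Measured in a functional assay on PC-3 cells (Homo sapiens) for antiproliferative activity, read by MTT assay, with a stated time of 24 h; a higher number here means a weaker inhibitor, a lower number a stronger inhibitor:
Compound 1 `CCn1c(C(=O)NCCN)ccc1C(CC)(CC)c1ccc(OCS(=O)(=O)c2ccccc2)c(C)c1` gives 6890 nM
Compound 2 `CCn1c(C(=O)N[C@H](C)C(=O)O)ccc1C(CC)(CC)c1ccc(OCS(=O)(=O)c2ccccc2)c(C)c1` gives 20100 nM
Compound 3 `CCn1c(C(=O)NC2(C(=O)O)CC2)ccc1C(CC)(CC)c1ccc(OCS(=O)(=O)c2ccccc2)c(C)c1` gives 26300 nM

These three share one core and differ only in the group on an amide-type nitrogen. Compound 2 and compound 3 lie within the scatter of each other, and together they form the weak end of this small set. The steps that separate them from the aminoethyl compound are a 2.9-fold higher number from compound 1 to compound 2 (0.46 log units; beyond the scatter) and a 3.8-fold higher number from compound 1 to compound 3 (0.58 log units; beyond the scatter), both modest.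

Going to compound 4 `CCn1c(C(=O)N[C@@H](CCC(=O)O)C(=O)O)ccc1C(CC)(CC)c1ccc(OCS(=O)(=O)c2ccccc2)c(C)c1`, 1,3-dicarboxypropyl takes the place of 1-carboxycyclopropyl on an amide-type nitrogen, and the swap counts as 1,3-dicarboxypropyl in place of 1-carboxycyclopropyl on an amide-type nitrogen with the core untouched. Going by the values given here, the closest precedent also trades one carboxy-bearing group for another, and it is a 1.3-fold higher number from compound 2 to compound 3 (0.12 log units; within the scatter). The two modest steps both leave 2-aminoethyl, which this change does not do, so they bear on it less. Among the compounds with values here, no measured compound carries 1,3-dicarboxypropyl, which leaves real uncertainty. Even so, no step beyond the scatter is expected in this assay. The estimated step is a 1.1-fold higher number from compound 3 to compound 4 (0.06 log units; within the scatter) as a best guess. Compound 4 is estimated at 30000 nM, with 13000 nM to 70000 nM as the expected range.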

Compound 4, half-maximal inhibitory concentration: > 50000 nM
Compound 4: a limit, no number (the forecaster's own chance of this, stated with the estimate: 15%); middle value at least 1.6-fold (0.22 log units) from the limit.
By their numbers in this assay, from the lowest: compound 1; then compounds 2 and 3 (each within the scatter of the next). At a limit, above all of these: compound 4.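

In this assay compound 4 gives a limit and not a number: the limit of > 50000 nM in this assay, at which 1 of the 4 values shown sits.

The floor of an at least 1.9-fold higher number from compound 3 to compound 4 (0.27 log units; that floor lies within the scatter) does not by itself separate 1,3-dicarboxypropyl from 1-carboxycyclopropyl, whereas an at least 2.4-fold higher number from compound 2 to compound 4 (0.39 log units; beyond the scatter) does separate it from 1-carboxyethyl, and an at least 7.2-fold higher number from compound 1 to compound 4 (0.86 log units; beyond the scatter) places it well away from 2-aminoethyl. Trading one carboxy-bearing group for another on this amide-type nitrogen is therefore not always a silent change: compound 2 and compound 3 sat within the scatter of each other, yet compound 4 stands clear of compound 2, though not, on this floor, of compound 3.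

From the compounds shown here alone, how far beyond its limit compound 4 really lies stays unknown, so the true size of all three steps remains open. Also open, going by these compounds, is which part of 1,3-dicarboxypropyl matters, the second carboxylic acid or the longer chain, and a longer chain ending in a single carboxylic acid, set against one ending in an amine, would help to tell these apart.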